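This account rests on a few compounds, and the source may have more. Where it says the series, first, only, none or still open, it means among the compounds named here.

Among the compounds with values here, in a functional assay on HEL cells (Homo sapiens) for antiproliferative activity, read by MTT assay, with a stated time of 72 h (on this read-out higher numbers stand for weaker inhibition and lower numbers for stronger inhibition), compound 1 (`CCCCCCCC(=O)Oc1cc(C(=O)C2=C3OC(C)(C)[C@@H](CC=C(C)C)C[C@@]34C[C@@H](CC=C(C)C)C(C)(C)[C@H]3CCC(C)(C)O[C@]34OC2=O)ccc1O`) gives 18700 nM, the only actual number available in this small set. Compound 2 (`CC(C)=CC[C@H]1C[C@]23C[C@@H](CC=C(C)C)C(C)(C)[C@H]4CCC(C)(C)O[C@]42OC(=O)C(C(=O)c2ccc(OC(=O)c4ccccc4)c(OC(=O)c4ccccc4)c2)=C3OC1(C)C`) is reported only as a limit, > 20000 nM. Compound 3 (`CCC(=O)Oc1cc(C(=O)C2=C3OC(C)(C)[C@@H](CC=C(C)C)C[C@@]34C[C@@H](CC=C(C)C)C(C)(C)[C@H]3CCC(C)(C)O[C@]34OC2=O)ccc1O`) has yet to be measured and differs from compound 1 in one place: hydrogen in place of pentyl on a saturated chain carbon, two bonds along the chain from a carbonyl carbon. This puts hydrogen in place of pentyl on a saturated chain carbon, two bonds along the chain from a carbonyl carbon, so heptylcarbonyl becomes propanoyl. Within the data shown here, no measured pair shows what such a change does, so the expectation starts from compound 1 at 18700 nM. A small move towards stronger inhibition is expected, possibly none beyond the scatter, and the estimated step is a 1.6-fold lower number from compound 1 to compound 3 (0.19 log units; within the scatter). In this assay the expected value for compound 3 is 12000 nM, with an estimated range of 5000 nM to 25000 nM.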

Compound 3, half-maximal inhibitory concentration: 9710 nM
Compound 3: the middle estimate sits 1.2-fold (0.09 log units) above what was measured; measured number inside the range.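

In this assay, putting hydrogen in place of pentyl, so that heptylcarbonyl becomes propanoyl, gives a 1.9-fold lower number from compound 1 to compound 3 (0.28 log units; within the scatter). Within the data shown here, this is the first step that can be read at this position, and it shows that this large change in the chain, with five carbons leaving, does not move the number clear of the usual scatter. Compound 2 is reported only as a limit and not a number, so no step to it can be read: the limit of > 20000 nM in this assay, at which 1 of the 3 values shown sits.

With only heptylcarbonyl and propanoyl compared at this position, the two chains say nothing about a trend with chain length. On these data alone, it remains open how this assay would respond to acetyl, to a chain longer than heptylcarbonyl, or to a chain ending in an amine or a carboxylic acid.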